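Carbonyl five-membered ring swap: compound 2 to compound 3

The source may hold more compounds than are shown below. What is called first, only, known or untested is meant among the compounds shown, and "the series" means these compounds.

Compound 1 `COc1ccc(-c2cc3ccccc3nc2/C=C/C(=O)c2ccc(OC)c(OC)c2)cc1` gives 7540 nM in a functional assay on NCI-H460 cells (Homo sapiens) for antiproliferative activity, read by XTT assay, with a stated time of 72 h; on this read-out higher numbers stand for weaker inhibition and lower numbers for stronger inhibition. Compound 2 `COc1ccc(-c2cc3ccccc3nc2/C=C/C(=O)c2ccc[nH]2)cc1` returns only a limit of this assay, > 10000 nM. The one measured step, an at least 1.3-fold higher number from compound 1 to compound 2 (0.12 log units; that floor lies within the scatter), therefore rests on a floor (the limit of > 10000 nM in this assay, at which 1 of the 2 values shown sits), and on the numbers shown compound 2 sits at the weak end of the series, with its true value unknown beyond that limit.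

Compound 3 `COc1ccc(-c2cc3ccccc3nc2/C=C/C(=O)c2sccc2N)cc1` differs from compound 2 by 3-aminothiophen-2-yl in place of 1H-pyrrol-2-yl on a carbonyl carbon. Going by the values given here, the only measured step, an at least 1.3-fold higher number from compound 1 to compound 2 (0.12 log units; that floor lies within the scatter), touches the same carbonyl position but is itself a floor within the scatter, so it gives no direction for this change. In this assay the expected step is a step that the limit leaves unreadable from compound 2 to compound 3, that is, none beyond the scatter, with a fair chance that only a limit is again reported. Compound 3 is estimated at 12000 nM, with a range from 3000 nM to 40000 nM.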

Compound 3, half-maximal inhibitory concentration: > 10000 nM
Compound 3: no number, only a limit; the forecaster's own chance of this, stated with the estimate: 55%; the middle value is on the limit's open side.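

The carbonyl position now carries a second five-membered ring, 3-aminothiophen-2-yl, and compound 3 also ends at a limit of the assay rather than a number: the limit of > 10000 nM in this assay, at which 2 of the 3 values shown sit.

In this assay, 3-aminothiophen-2-yl in place of 3,4-dimethoxyphenyl on a carbonyl carbon gives an at least 1.3-fold higher number from compound 1 to compound 3 (0.12 log units; that floor lies within the scatter), a floor and not a size, so this change, like the one to 1H-pyrrol-2-yl, has no readable magnitude. The step between the two five-membered rings cannot be read, so the series does not separate 1H-pyrrol-2-yl from 3-aminothiophen-2-yl.

On these data alone, how far compound 2 and compound 3 lie past the limit remains open. Also open, as far as these compounds go, is whether a plain thiophen-2-yl or a 3-aminophenyl on this carbonyl carbon would return a number in this assay.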